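The compounds below may be only part of what the source reports. "The series", "measured", "known", "first", "only" and "open" are said of these compounds alone.

Measured compounds in a functional assay on PC-3 cells (Homo sapiens) for antiproliferative activity, read by MTT assay, with a stated time of 48 h; a lower number here means a stronger inhibitor, a higher number a weaker inhibitor:
- compound 1, `CCn1c(C(=O)NCCCN(C)C)ccc1C(CC)(CC)c1ccc(OCCC(O)(CC)CC)c(C)c1`: 2150 nM
- compound 2, `CCN(CC)CCNC(=O)c1ccc(C(CC)(CC)c2ccc(OCCC(O)(CC)CC)c(C)c2)n1CC`: 3350 nM
- compound 3, `CCn1c(C(=O)NCC#N)ccc1C(CC)(CC)c1ccc(OCCC(O)(CC)CC)c(C)c1`: 17800 nM

Compound 1 gives the lowest number of the three. Compound 2 sits close to it, since the step of a 1.6-fold higher number from compound 1 to compound 2 (0.19 log units; within the scatter) stays within the scatter. Compound 3 lies clearly further away, with the step of an 8.3-fold higher number from compound 1 to compound 3 (0.92 log units; beyond the scatter) going beyond the scatter; the step of a 5.3-fold higher number from compound 2 to compound 3 (0.73 log units; beyond the scatter) points the same way.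

Compound 4, `CCOC(=O)C(CC(=O)OC)NC(=O)c1ccc(C(CC)(CC)c2ccc(OCCC(O)(CC)CC)c(C)c2)n1CC`, is compound 1 with a different group on the amide nitrogen: a group of 11 heavy atoms (7 carbon, 4 oxygen; no ring) in place of a group of 6 heavy atoms (5 carbon, 1 nitrogen; no ring), on an amide-type nitrogen

For the measured compounds named here, the steps that bear on this change are those to compound 3, where the chain carrying a nitrogen was exchanged for cyano and the number rose modestly, as an 8.3-fold higher number from compound 1 to compound 3 (0.92 log units; beyond the scatter) and a 5.3-fold higher number from compound 2 to compound 3 (0.73 log units; beyond the scatter) show. Compound 4 likewise loses the 3-(dimethylamino)propyl group, so a step of similar size and direction is expected, namely a 7.0-fold higher number from compound 1 to compound 4 (0.84 log units; beyond the scatter). Compound 4 is therefore estimated at 15000 nM, with a range from 5000 nM to 45000 nM.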

Compound 4, half-maximal inhibitory concentration: 5840 nM
For compound 4 the middle estimate is 2.6-fold (0.41 log units) above the measured one, within the range that was stated.
By their numbers in this assay, from the lowest: compounds 1, 2 and 4 (each within the scatter of the next, the first and the last beyond it); then compound 3.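

In this assay the group of 11 heavy atoms, which holds no nitrogen, costs some ground against 3-(dimethylamino)propyl, with a 2.7-fold higher number from compound 1 to compound 4 (0.43 log units; beyond the scatter) on this amide-type nitrogen, yet the comparison with the diethylamino chain gives a 1.7-fold higher number from compound 2 to compound 4 (0.24 log units; within the scatter) and so no real separation. The cyano-ended chain stays clearly apart, as a 3.0-fold lower number from compound 3 to compound 4 (0.48 log units; beyond the scatter) shows, so losing the nitrogen of the chain does not by itself bring the number up to the level of compound 3. No measurement shown here explains these differences.

Compound 4 changes size and atom types together, so the effect of each stays unresolved. A carboxylic acid, a primary amine or a longer chain on this nitrogen would test how far this tolerance extends.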